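Working notes: compound 3 to compound 4

This account rests on a few compounds, and the source may have more. Where it says the series, first, only, none or still open, it means among the compounds named here.

Among the compounds with values here, in a functional assay on M21 cells (Homo sapiens) for antiproliferative activity, read by sulforhodamine B assay, with a stated time of 48 h (a lower number here means a stronger inhibitor, a higher number a weaker inhibitor), compound 3 `CCCN1CCN(c2ccc(S(=O)(=O)Oc3cccc(OC)c3)cc2)C1=O` gives 10000 nM, the only actual number so far. Compound 1 `Cc1ccc(OS(=O)(=O)c2ccc(N3CCN(C)C3=O)cc2)cc1` reads > 100000 nM, which is a limit of the assay. Compound 2 `CCCN1CCN(c2ccc(S(=O)(=O)Oc3ccccc3CC)cc2)C1=O` reads > 50000 nM, also a limit.

Compound 4 `CCCN1CCN(c2ccc(S(=O)(=O)Oc3ccc(C)cc3)cc2)C1=O` has not been measured. The change is 4-methylphenyl in place of 3-methoxyphenyl on an oxygen, with 4-methylphenyl in place of 3-methoxyphenyl on an oxygen whose other neighbour is the sulfonyl sulfur.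

Within the data shown here, one measured step touches this place: an at least 5.0-fold lower number from compound 2 to compound 3 (0.69 log units; beyond the scatter), with 3-methoxyphenyl in place of 2-ethylphenyl. It shows that the group on this oxygen can move the reading in this assay beyond the scatter, and its size is open-ended because one end is a limit. The 4-methylphenyl group itself appears only in compound 1, whose reading of > 100000 nM is a limit and whose core differs from that of compound 4. This points towards weaker inhibition, though only loosely.

The estimated change is a 2.5-fold higher number from compound 3 to compound 4 (0.40 log units; beyond the scatter), a modest move to a higher number. For compound 4 the expected value is 25000 nM, with an estimated range of 6000 nM to 100000 nM.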

Compound 4, half-maximal inhibitory concentration: 28000 nM
Compound 4: the middle estimate sits 1.1-fold (0.05 log units) below what was measured, within the range that was stated.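

In this assay, within the data shown here, there is a 2.8-fold higher number from compound 3 to compound 4 (0.45 log units; beyond the scatter), the first step at this oxygen with a real number at both ends, so 4-methylphenyl in place of 3-methoxyphenyl is a measured move to a higher number and not one bounded by a limit. With ethyl in place of hydrogen on a saturated chain carbon bound to an amide-type nitrogen in a ring, there is an at least 3.5-fold lower number from compound 1 to compound 4 (0.55 log units; beyond the scatter), and its size stays open-ended since compound 1 stands at a limit: the limit of > 100000 nM in this assay, at which 1 of the 4 values shown sits. With 4-methylphenyl in place of 2-ethylphenyl on an oxygen, there is an at least 1.7-fold lower number from compound 2 to compound 4 (0.25 log units; that floor lies within the scatter), so these two groups cannot be put in order since compound 2 stands at a limit: the limit of > 50000 nM in this assay, at which 1 of the 4 values shown sits.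

3-methoxyphenyl and 4-methylphenyl differ in more than one way, and the compounds shown do not separate those differences. Also open, from the compounds shown here alone, is how an amine or a carboxylic acid on this aromatic ring, or a longer chain on the amide-type nitrogen in a ring, would read in this assay.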